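A few compounds are considered here, and "the series" means these few. Any claim that something is new, unique, unknown or untested is made for them only; others in the source may bear on it.

Going by the values given here, in a functional assay on KYSE-450 cells (Homo sapiens) for inhibition, read by CCK-8 assay, with a stated time of 48 h (a higher number here means a weaker inhibitor, a lower number a stronger inhibitor), compound 2 (`COc1ccc(CN(C(=O)CSC(=S)N2CCc3ccccc32)c2cc(OC)c(OC)c(OC)c2)cc1`) gives 6940 nM, the higher of the two numbers so far, while compound 1 (`COc1ccc(CN(C(=O)CSc2nc3ccccc3o2)c2cc(OC)c(OC)c(OC)c2)cc1`) gives 840 nM. Compound 3 (`CCN1CCN(CC(=O)N(Cc2ccc(OC)cc2)c2cc(OC)c(OC)c(OC)c2)CC1`) carries this change: a group of 8 heavy atoms (6 carbon, 2 nitrogen; one six-membered non-aromatic ring with 2 hetero atoms) in place of a group of 12 heavy atoms (9 carbon, 1 nitrogen, 2 sulfur; one five-membered non-aromatic ring with 1 hetero atom, one six-membered aromatic ring of carbon only), on a saturated chain carbon bound to a carbonyl carbon. Among the compounds with values here, the only measured step bearing on it is an 8.3-fold higher number from compound 1 to compound 2 (0.92 log units; beyond the scatter), a modest one beyond the scatter, made on a sulfur and so only an indirect guide. A smaller step, toward a lower number, is therefore expected in this assay. The expected step is a 2.8-fold lower number from compound 2 to compound 3 (0.44 log units; beyond the scatter). For compound 3 the estimated value is 2500 nM, with an expected range of 500 nM to 12000 nM.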

Compound 3, half-maximal inhibitory concentration: 16100 nM
Beside the measured number, compound 3's estimate is 6.4-fold (0.81 log units) below it; measured number outside the range, above it.
By their numbers in this assay, from the lowest: compound 1; then compound 2; then compound 3.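

In this assay, 4-ethylpiperazin-1-yl on the saturated chain carbon bound to a carbonyl carbon gives a weaker result than either sulfur-linked group: a 2.3-fold higher number from compound 2 to compound 3 (0.37 log units; beyond the scatter), and a 19-fold higher number from compound 1 to compound 3 (1.28 log units; beyond the scatter). At this position, (1,3-benzoxazol-2-yl)sulfanyl therefore remains the best of the three groups shown. Nothing available explains this order.

Going by these compounds, it remains open whether the ring nitrogens or the absence of the sulfur link accounts for the rise. A morpholine, an unsubstituted piperazine or a benzoxazole attached without sulfur would help separate these two changes.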